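This account rests on a few compounds, and the source may have more. Where it says the series, first, only, none or still open, it means among the compounds named here.

The measured compounds:
Compound 1 `CCCc1nnc(SCc2ccccc2)n1N1C(=O)c2ccccc2C1=O` in a functional assay on MKN-45 cells (Homo sapiens) for cytotoxicity, read by MTT assay, with a stated time of 48 h (on this read-out lower numbers stand for stronger inhibition and higher numbers for weaker inhibition), gives > 200000 nM; this is a limit of the assay, not a number.
Compound 2 `CCCc1nnc(SCC(=O)c2ccc(Cl)cc2)n1N1C(=O)c2ccccc2C1=O` in this assay gives > 200000 nM; this too is a limit.
Compound 3 `C#CCSc1nnc(CCC)n1N1C(=O)c2ccccc2C1=O` in this assay gives > 200000 nM; again only a limit.

Compound 3 therefore stands nowhere on a scale: its value is a limit, and all three measured compounds sit at the same place, (the limit of > 200000 nM in this assay, at which 3 of the 3 values shown sit). The steps that touch the group on the saturated chain carbon bound to a sulfur are a step that the two limits leave unreadable from compound 1 to compound 3 and a step that the two limits leave unreadable from compound 2 to compound 3, and the third one, a step that the two limits leave unreadable from compound 1 to compound 2, is likewise unreadable. For the measured compounds named here, no measured step gives a size or a direction.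

Compound 4 `CCCc1nnc(SC)n1N1C(=O)c2ccccc2C1=O` differs from compound 3 by hydrogen in place of ethynyl on a saturated chain carbon bound to a sulfur. Since every step at this position is hidden by the limit, no step beyond the scatter can be read or predicted in this assay; the most likely outcome is that compound 4 also returns a limit. Compound 4 is estimated at 300000 nM, with a range from 100000 nM to 1000000 nM. The step that the limit leaves unreadable from compound 3 to compound 4 is what this estimate would mean, and it is expected to stay unreadable.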

Compound 4, half-maximal inhibitory concentration: > 200000 nM
Compound 4 was reported as a limit; the forecaster's own chance of this, stated with the estimate: 85%; the middle value is on the limit's open side.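

Compound 4 returns only a limit in this assay, as do compound 1, compound 2 and compound 3, so none of the steps among these four compounds can be read: the limit of > 200000 nM in this assay, at which 4 of the 4 values shown sit.

The compounds shown leave open whether any group on the saturated chain carbon bound to a sulfur alters the read-out, and in which direction.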